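Removing the methyl from compound 2: what to expect

A few compounds are considered here, and "the series" means these few. Any claim that something is new, unique, unknown or untested is made for them only; others in the source may bear on it.

The series is followed in a functional assay for inhibition, with Homo sapiens as the target; on this read-out lower numbers stand for stronger inhibition and higher numbers for weaker inhibition. Compound 1, `COc1cccc(Nc2nccc(-c3cccs3)n2)c1`, gives 900 nM in this assay. Compound 3, `COc1ccc(Nc2nccc(-c3ccncc3)n2)cc1`, gives 4200 nM in this assay. Compound 2, `COc1cccc(Nc2nc(C)cc(-c3ccncc3)n2)c1`, sits at the limit of this assay, and its value of > 24000 nM is a limit rather than a number; this is the situation described by the limit of > 24000 nM in this assay, at which 1 of the 3 values shown sits. So compound 2 stands at the weak end of what has been recorded, with no measured number of its own.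

The compound still to be measured is compound 4, `COc1cccc(Nc2nccc(-c3ccncc3)n2)c1`. It differs from compound 2 in one place: hydrogen in place of methyl on an aromatic carbon. Within the data shown here, the change is small in atom count, but no pair of measured compounds shows the same step, so the direction can only be inferred. Compound 1 and compound 3, both without a methyl on the shared core, gave measurable numbers, whereas compound 2, which carries the methyl, did not. On that basis, the step from compound 2 to compound 4 is expected to move toward stronger inhibition, so that compound 4 is expected at 3000 nM, between 800 nM and 12000 nM. The step that this estimate for compound 4 implies is an at least 8.0-fold lower number from compound 2 to compound 4 (0.90 log units; beyond the scatter).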

Compound 4, half-maximal inhibitory concentration: 400 nM
For compound 4 the middle estimate is 7.5-fold (0.88 log units) above the measured one; measured number below the stated range.
By their numbers in this assay, from the lowest: compound 4; then compound 1; then compound 3. At a limit, above all of these: compound 2.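

In this assay the change from methyl to hydrogen on the aromatic carbon next to the ring nitrogen gives an at least 60-fold lower number from compound 2 to compound 4 (1.77 log units; beyond the scatter) and is the only step shown at this position. The exchange of thiophen-2-yl for pyridin-4-yl on the shared core gives a 2.3-fold lower number from compound 1 to compound 4 (0.35 log units; beyond the scatter) and is modest beside the change at the methyl position, so among the steps shown, the larger one belongs to the single carbon that leaves. The first of these steps is bounded on one side only, as the value of compound 2 is a limit and not a number: the limit of > 24000 nM in this assay, at which 1 of the 4 values shown sits.

Only hydrogen and methyl are shown at this position, so what an ethyl group, an amine or a chlorine atom on the same aromatic carbon would do in this assay stays open. The compounds shown also leave open whether a methyl at this position would weigh as heavily with thiophen-2-yl in place of pyridin-4-yl on the shared core, and so whether the step holds beyond this one pair.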